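A few compounds are considered here, and "the series" means these few. Any claim that something is new, unique, unknown or untested is made for them only; others in the source may bear on it.

Of the compounds shown here, three sharing one core have so far been tested in an ADME assay on BJ cells (Homo sapiens) for cytotoxicity, with a stated time of 72 h (on this read-out higher numbers stand for an effect only at larger amounts of compound and lower numbers for an effect already at smaller amounts), to gauge how toxic they are to cells. Compound 1 (`Cc1cc(NC(=O)Nc2ccc(C)c(Cl)c2)c2ccccc2n1`) gives > 25000 nM as a limit of the assay and not a number. Compound 2 (`CSc1ccc(NC(=O)Nc2cc(C)nc3ccccc23)cc1`) gives > 25000 nM, which is also a limit. Compound 3 (`CC(=O)c1ccc(NC(=O)Nc2cc(C)nc3ccccc23)cc1`) gives 22000 nM and is the only one of the three with a true number. Its exact standing cannot be read because of the limit of > 25000 nM in this assay, at which 2 of the 3 values shown sit, in this series.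

The next change leads to compound 4 (`Cc1ccc(NC(=O)Nc2cc(C)nc3ccccc23)cc1`), which has methyl in place of acetyl on an aromatic carbon, para to a large group: methyl in place of acetyl on an aromatic carbon in all.

Going by the values given here, one measured step bears on this, since it brought in the same acetyl group that now leaves. That step is an at least 1.1-fold lower number from compound 2 to compound 3 (0.05 log units; that floor lies within the scatter) and gives no sign of a real effect from changing the group at this place. No step beyond the scatter is therefore expected, and the estimated change is a 1.2-fold higher number from compound 3 to compound 4 (0.07 log units; within the scatter) in this assay.

For compound 4 the estimated value is 26000 nM with an expected range from 14000 nM to 50000 nM in this assay, and a report of only a limit would be no surprise.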

Compound 4, half-maximal effective concentration: > 25000 nM
Compound 4 ended at the assay's limit (the forecaster's own chance of this, stated with the estimate: 65%); the middle value does not contradict the limit.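

In this assay, the change from acetyl to methyl on the aromatic carbon para to a large group gives an at least 1.1-fold higher number from compound 3 to compound 4 (0.05 log units; that floor lies within the scatter), so even the smallest change this step could represent cannot be told apart from ordinary variation between repeated measurements. Going by these compounds alone, this is the first look at this place with the acetyl group replaced by a group smaller than methylsulfanyl, one with no hydrogen-bond acceptor, and the result still shows no real effect: with acetyl, methylsulfanyl and now methyl at this place, no readable step goes beyond the scatter, and compound 3 remains the only compound with a true number. The steps to compound 4 from compound 1 and from compound 2 cannot be read, because both ends of each step are limits and not numbers: the limit of > 25000 nM in this assay, at which 3 of the 4 values shown sit.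

Going by these compounds, whether an amine or a carboxylic acid at this place, or a longer chain, would give a step beyond the scatter remains open. Also open, on these data alone, is how far past the limit of the assay compound 1, compound 2 and compound 4 really lie, so a larger step from compound 3 to compound 4 cannot be ruled out.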